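This account rests on a few compounds, and the source may have more. Where it says the series, first, only, none or still open, it means among the compounds named here.

Compound 1 `Cc1cccc2sc(NC(=O)CCN3CCN(C(C)(C)C)CC3)nc12` gives 147 nM in an assay on membranes from brain for displacement of a labelled ligand from Sigma non-opioid intracellular receptor 1 (Cavia porcellus), read by scintillation counting, with a stated time of 120 min; on this read-out higher numbers stand for weaker inhibition and lower numbers for stronger inhibition; compound 2 `Cc1ccccc1N1CCN(CCC(=O)Nc2nc3c(C)cccc3s2)CC1` gives 1000 nM.

Compound 2 stands highest of these two numbers, reached by a 6.8-fold higher number from compound 1 to compound 2 (0.83 log units; beyond the scatter). Compound 3 `Cc1cccc2sc(NC(=O)CCN3CCN(c4ccncc4)CC3)nc12` differs from compound 2 by pyridin-4-yl in place of 2-methylphenyl on an amine nitrogen in a ring. Within the data shown here, no measured step covers the exchange of one aromatic ring for another at this position; the single known step concerns an alkyl group giving way to an aryl group, so it bears only loosely here. Compound 3 is therefore expected to move little from its parent, a 1.3-fold higher number from compound 2 to compound 3 (0.11 log units; within the scatter), with no firm direction. The estimate for compound 3 is 1300 nM, within 350 nM to 5000 nM.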

Compound 3, inhibition constant: 9600 nM
Compound 3: the middle estimate sits 7.4-fold (0.87 log units) below what was measured, outside the stated range (above it).
By their numbers in this assay, from the lowest: compound 1; then compound 2; then compound 3.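

In this assay, this place on the amine nitrogen in a ring proves sensitive to which aromatic ring it carries, not only to whether it carries an alkyl or an aryl group: pyridin-4-yl in place of 2-methylphenyl gives (a 9.6-fold higher number from compound 2 to compound 3 (0.98 log units; beyond the scatter)). Measured against tert-butyl, the same group gives (a 65-fold higher number from compound 1 to compound 3 (1.81 log units; beyond the scatter)), which leaves compound 3 the weakest of the three. No evidence at hand explains this change. The compounds shown leave open whether losing the methyl or gaining the ring nitrogen carries the step, and how an unsubstituted phenyl or a cyclohexyl group would read here.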